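The source may hold more compounds than are shown below. What is called first, only, known or untested is meant among the compounds shown, and "the series" means these compounds.

In a functional assay on HT cells (Homo sapiens) for cytotoxicity, read by CCK-8 assay, with a stated time of 72 h (a lower number here means a stronger inhibitor, a higher number a weaker inhibitor), compound 1 `Cn1cc(NC(=O)c2cnc3ccc(N[C@H]4CCCNC4)nn23)c(C(F)F)n1` reads > 50000 nM as a limit of the assay and not a number. Within the data shown here, compound 2 `Cn1cc(NC(=O)c2cnc3ccc(N[C@@H]4CCCCNC4)nn23)c(C(F)F)n1` gives 35900 nM in this assay, which is the only true number so far, so it cannot yet be ranked against any other number. Among the measured compounds shown here, the one measured step, azepan-3-yl in place of piperidin-3-yl on a nitrogen on an aromatic ring, is an at least 1.3-fold lower number from compound 1 to compound 2 (0.14 log units; that floor lies within the scatter) and offers only a floor for its size. The reading range also matters here, given the limit of > 50000 nM in this assay, at which 1 of the 2 values shown sits, as the ceiling.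

Compound 3 `Cn1cc(NC(=O)c2cnc3ccc(NCCN)nn23)c(C(F)F)n1` brings a larger edit, namely 2-aminoethyl in place of azepan-3-yl on a nitrogen on an aromatic ring in the change of 2-aminoethyl in place of azepan-3-yl on a nitrogen on an aromatic ring. For the measured compounds named here, no measured step covers a switch from a ring to an open chain. With compound 2 at 35900 nM and no measured change beyond the scatter, no clear step is expected in this assay. The expected change is a 1.1-fold higher number from compound 2 to compound 3 (0.05 log units; within the scatter) and a limit reading would be no surprise. For compound 3 the expected value is 40000 nM with an estimated range from 15000 nM to 60000 nM as the likely span.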

Compound 3, half-maximal inhibitory concentration: > 50000 nM
Compound 3: a limit, no number (the forecaster's own chance of this, stated with the estimate: 50%); middle value at least 1.2-fold (0.09 log units) from the limit.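

Swapping the seven-membered azepan-3-yl ring on a nitrogen on an aromatic ring for the open 2-aminoethyl chain, which has no ring and no defined stereocentre, gives an at least 1.3-fold higher number from compound 2 to compound 3 (0.14 log units; that floor lies within the scatter). Among these compounds, this is the first look at an open chain at this position, and the floor on the change is too small to show that the ring matters in this assay. Compound 3 reads as a limit of the assay and not a number, so the true size of the change stays hidden, and the ceiling now holds most of the set: the limit of > 50000 nM in this assay, at which 2 of the 3 values shown sit. The step from compound 1 to compound 3 joins two limits and cannot be read.

Going by these compounds, it remains open whether a longer chain such as 3-aminopropyl, or a carboxylic acid in place of the end amine, would give a clear number in this assay. The same question stands for a piperidin-4-yl ring, and with so few true numbers, no ranking of the groups at this position can yet be drawn.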